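Aryl Swap on the Shared Core: Compound 2 to Compound 3

The source may hold more compounds than are shown below. What is called first, only, known or untested is meant among the compounds shown, and "the series" means these compounds.

compound 1 `Cc1nnc(NC(=O)/C(C#N)=C/c2cccc(OS(C)(=O)=O)c2)s1`: 20%
compound 2 `COc1ccc(-c2nnc(NC(=O)/C(C#N)=C/c3cccc(OS(=O)(=O)c4ccc(C)cc4)c3)s2)cc1`: 73%

In a functional assay on HL-60 cells (Homo sapiens) for inhibition, read by CCK-8 assay, with a stated time of 48 h, tested at 20 uM (on this read-out higher numbers stand for more inhibition of growth at the one concentration tested and lower numbers for less inhibition of growth), compound 2 gives 73%, the higher of the two numbers. Compound 1 gives 20% in the same assay, a gap beyond the usual scatter. Compound 3 `Cc1ccc(S(=O)(=O)Oc2cccc(/C=C(\C#N)C(=O)Nc3nnc(-c4cccs4)s3)c2)cc1` keeps the rest of compound 2 and differs by thiophen-2-yl in place of 4-methoxyphenyl on an aromatic carbon. Going by the values given here, no pair of measured compounds isolates this change, so its size is uncertain; a small drop, or none beyond the scatter, is the expected step of a number 11 percentage points lower from compound 2 to compound 3 (beyond the scatter). Compound 3 is expected to give 62%, with a range from 40% to 80%.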

Compound 3, percent growth inhibition at one concentration: 62%
Estimate against measurement, compound 3: no gap at the digits printed, and the stated range covers the measured number.
By their numbers in this assay, from the lowest: compound 1; then compound 3; then compound 2.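

In this assay, going by these compounds alone, thiophen-2-yl in place of 4-methoxyphenyl gives a number 11 percentage points lower from compound 2 to compound 3 (beyond the scatter), the first step that isolates a change at this position. The position therefore accepts a five-membered aromatic ring with one hetero atom, with compound 3 still at 62%, though not without a modest loss. Nothing measured on these compounds explains the step.

Open, from the compounds shown here alone, is how an amine or a carboxylic acid at this position would read in this assay. Also open, going by these compounds, is how much of the low number of compound 1 belongs to this position, as it differs from compound 2 in more than one place.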